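Removing one chlorine from compound 2

The source may hold more compounds than are shown below. What is called first, only, known or untested is meant among the compounds shown, and "the series" means these compounds.

Measured so far in a functional assay on HCT-116 cells (Homo sapiens) for inhibition, read by resazurin assay, with a stated time of 5 days; on this read-out higher numbers stand for weaker inhibition of growth and lower numbers for stronger inhibition of growth:
Compound 1 `O=C(CCCC1CCN(S(=O)(=O)c2ccc(C(F)(F)F)cc2)CC1)NO`: "not determined" (no result reported)
Compound 2 `O=C(CCCC1CCN(S(=O)(=O)c2ccccc2Cl)CC1)NO`: 2800 nM

Going by the values given here, compound 2 holds the only number available, so it cannot yet be ranked against anything. Compound 1 offers no comparison without a result. The next compound to be tested is compound 3 `O=C(CCCC1CCN(S(=O)(=O)c2ccccc2)CC1)NO`, which keeps the core of compound 2 and makes one small edit: hydrogen in place of chloro on an aromatic carbon. In words, hydrogen takes the place of chloro on an aromatic carbon, so a 2-chlorophenyl group becomes a phenyl group. Among the compounds with values here, with no measured pair to show what a single change does here, any forecast is cautious, and a wide range is needed. The expected step of a 1.1-fold lower number from compound 2 to compound 3 (0.05 log units; within the scatter) is none beyond the usual scatter of repeated measurements in this assay. For compound 3 the estimated value is 2500 nM, with an expected range from 900 nM to 7000 nM.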

Compound 3, concentration for 50% growth inhibition: 2700 nM
Compound 3: middle estimate off by 1.1-fold (0.03 log units), on the low side; the range from low to high includes it.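

Going by these compounds alone, this is the first measured pair that differs in one place. In this assay the swap of 2-chlorophenyl for phenyl gives a 1.0-fold lower number from compound 2 to compound 3 (0.02 log units; within the scatter), so the two compounds cannot be told apart, and growth inhibition at this level does not depend on the chloro group on this aromatic carbon, ortho to a large group. No available measurement offers an explanation for this result.

Going by these compounds, one small atom swapped for another tests this carbon only lightly, so it remains open whether a larger or very different group there, such as a methoxy group, an amine or a carboxylic acid, would also leave the read-out in the same range. On these data alone, it is also open whether a longer chain in the shared core would matter more than anything on this aromatic ring.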